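This account rests on a few compounds, and the source may have more. Where it says the series, first, only, none or still open, it means among the compounds named here.

Measured in a functional assay on DU-145 cells (Homo sapiens) for inhibition, read by trypan blue exclusion, with a stated time of 96 h; on this read-out higher numbers stand for weaker inhibition of growth and lower numbers for stronger inhibition of growth:
- compound 1 `O=C(/C(=C\c1c(O)cc(O)cc1O)S(=O)(=O)c1ccccc1Br)c1ccc(Cl)cc1`: 50000 nM
- compound 2 `O=C(/C(=C\c1c(O)cc(O)cc1O)SCc1ccc(Cl)cc1)c1ccc(Cl)cc1`: > 100000 nM (a limit, not a number)
- compound 3 `Cc1ccc(S/C(=C/c2c(O)cc(O)cc2O)C(=O)c2ccc(Cl)cc2)cc1`: > 100000 nM (a limit, not a number)

Compound 3 has no exact value and stands at the limit of > 100000 nM in this assay, at which 2 of the 3 values shown sit. Compound 2 is the other compound there, so a step that the two limits leave unreadable from compound 2 to compound 3 tells little.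

Compound 4 `O=C(/C(=C\c1c(O)cc(O)cc1O)Sc1ccc(Br)cc1)c1ccc(Cl)cc1` is compound 3 with one swap: bromo in place of methyl on an aromatic carbon, para to a large group (bromo in place of methyl on an aromatic carbon).

Among the measured compounds shown here, no measured step tests this swap directly. The nearest steps change the whole group on the chain carbon: an at least 2.0-fold higher number from compound 1 to compound 2 (0.30 log units; that floor lies within the scatter), and an at least 2.0-fold higher number from compound 1 to compound 3 (0.30 log units; that floor lies within the scatter). Both are only floors, and neither involves a methyl or a bromo on this ring.

With compound 2 and compound 3 sharing (the limit of > 100000 nM in this assay, at which 2 of the 3 values shown sit), a similar sulfanyl compound is expected to stay near that limit. The expected change is a number no higher from compound 3 to compound 4 (the limit leaves the size open), which means no step beyond the scatter. Compound 4 is estimated at about 100000 nM, with an expected range of 50000 nM to 200000 nM.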

Compound 4, concentration for 50% growth inhibition: 50000 nM
Estimate against measurement, compound 4: 2.0-fold (0.30 log units) above, within the range that was stated.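

Bromo in place of methyl on the aromatic carbon, para to a large group, gives an at least 2.0-fold lower number from compound 3 to compound 4 (0.30 log units; that floor lies within the scatter) in this assay, so this swap yields a sulfanyl compound with an exact value. Compound 2 and compound 3 remain at a limit, not a number: the limit of > 100000 nM in this assay, at which 2 of the 4 values shown sit. The 4-bromophenyl group in place of 4-chlorobenzyl on the sulfur gives an at least 2.0-fold lower number from compound 2 to compound 4 (0.30 log units; that floor lies within the scatter), while (4-bromophenyl)sulfanyl in place of (2-bromophenyl)sulfonyl gives no change at the digits printed from compound 1 to compound 4 (within the scatter), so among these compounds a readable value does not depend on the sulfonyl group.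

From the compounds shown here alone, the true size of the step from methyl to bromo stays open, with only a limit for compound 3. Also open, going by these compounds, is how an amine, a methoxy group or a carboxylic acid on that same aromatic carbon would read.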